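This account rests on a few compounds, and the source may have more. Where it says the series, first, only, none or still open, it means among the compounds named here.

Measured in a functional assay on HCC827 cells (Homo sapiens) for inhibition, read by fluorescence, with a stated time of 72 h; on this read-out higher numbers stand for weaker inhibition of growth and lower numbers for stronger inhibition of growth:
Compound 1 `CCCCCCn1cnc2c(Nc3ccc(Cl)cc3)nc(N[C@H]3CC[C@H](N)CC3)nc21` gives 11700 nM
Compound 2 `CCCCn1cnc2c(NCc3cccc(Cl)c3)nc(N[C@H]3CC[C@H](N)CC3)nc21` gives 10600 nM
Compound 3 `CC(C)CCn1cnc2c(NCc3cccc(Cl)c3)nc(N[C@H]3CC[C@H](N)CC3)nc21` gives 16700 nM

All three numbers lie within the scatter of one another, so compound 3 stands level with the other two. The change to compound 4 (`CC(C)CCn1cnc2c(Nc3ccccc3)nc(N[C@H]3CC[C@H](N)CC3)nc21`) is phenyl in place of 3-chlorobenzyl on a nitrogen on an aromatic ring. Going by the values given here, no measured step touches that group. Among the compounds with values here, the only measured step lies on the saturated chain (a 1.6-fold higher number from compound 2 to compound 3 (0.20 log units; within the scatter)) and stays within the scatter. Compound 1 also carries an aromatic ring directly on that nitrogen, with a different chain, and gives 11700 nM within the scatter of compound 3. The expected change in this assay therefore stays within the scatter, with no direction favoured (a 1.4-fold lower number from compound 3 to compound 4 (0.14 log units; within the scatter) is the estimate). For compound 4 the estimate is 12000 nM with an expected range from 5000 nM to 25000 nM on this read-out.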

Compound 4, concentration for 50% growth inhibition: 21700 nM
The estimate for compound 4 lay 1.8-fold (0.26 log units) below the measured number, within the range that was stated.
By their numbers in this assay, from the lowest: compounds 2, 1, 3 and 4 (each within the scatter of the next, the first and the last beyond it).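

In this assay the exchange of 3-chlorobenzyl for phenyl on the nitrogen on the aromatic ring stays within the scatter (a 1.3-fold higher number from compound 3 to compound 4 (0.11 log units; within the scatter)). Going by these compounds alone, this is the first measured step at this position, and with the chain of compound 3 held fixed, it shows that this position tolerates the change without a clear loss or gain. The step removes the chlorine and shortens the (3-chlorobenzyl)amino group to anilino in one move, so it cannot separate the two, and nothing measured bears on the reason for the result. The compounds shown leave open whether an amine or a carboxylic acid on the phenyl ring would move the number beyond the scatter.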